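This account rests on a few compounds, and the source may have more. Where it says the series, first, only, none or still open, it means among the compounds named here.

Compound 1, with structure `Oc1cccc(-c2cc(-c3ccccc3C(F)(F)F)cc(-c3ccccc3O)n2)c1`, is one of three measured compounds sharing a core built around a six-membered aromatic ring with one nitrogen. In a functional assay on DU-145 cells (Homo sapiens) for inhibition (a lower number here means a stronger inhibitor, a higher number a weaker inhibitor), compound 1 gives 7250 nM. Compound 2, with structure `Oc1cccc(-c2cc(-c3ccccc3C(F)(F)F)cc(-c3cccc(O)c3)n2)c1`, differs from compound 1 by a single change, (3-hydroxyphenyl in place of 2-hydroxyphenyl on an aromatic carbon), and in this assay compound 2 gives 2870 nM; the step is a 2.5-fold lower number from compound 1 to compound 2 (0.40 log units; beyond the scatter). Compound 3, with structure `Oc1ccccc1-c1cc(-c2ccc(OC(F)(F)F)cc2)cc(-c2ccccc2O)n1`, carries a different substituent on the core, and the difference between the core of compound 3 and the core of compound 1 is not broken down here. In this assay compound 3 gives 20300 nM, the highest of the three numbers.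

Compound 4, with structure `Oc1cccc(-c2cc(-c3ccc(OC(F)(F)F)cc3)cc(-c3ccccc3O)n2)c1`, has not yet been measured. It differs from compound 3 by 3-hydroxyphenyl in place of 2-hydroxyphenyl on an aromatic carbon. Going by the values given here, this is the same kind of change as the one from compound 1 to compound 2, though the surroundings of the place differ: in compound 1 the place is meta to a 2-(trifluoromethyl)phenyl group and meta to a 3-hydroxyphenyl group, whereas in compound 3 it is meta to a 2-hydroxyphenyl group and meta to a large group. The step from compound 3 to compound 4 in this assay is expected to be a 2.5-fold lower number from compound 3 to compound 4 (0.40 log units; beyond the scatter), a size resting on the step of a 2.5-fold lower number from compound 1 to compound 2 (0.40 log units; beyond the scatter) and on the value of compound 3 as its starting point. Compound 4 is therefore estimated to give 8000 nM in this assay, most likely between 4000 nM and 16000 nM.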

Compound 4, half-maximal inhibitory concentration: 21100 nM
Compound 4: middle estimate off by 2.6-fold (0.42 log units), on the low side; the whole stated range lies below it.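

On the core of compound 3, 3-hydroxyphenyl in place of 2-hydroxyphenyl gives a 1.0-fold higher number from compound 3 to compound 4 (0.02 log units; within the scatter) in this assay, so this pair cannot be told apart, whereas the same change on the core of compound 1 gives a 2.5-fold lower number from compound 1 to compound 2 (0.40 log units; beyond the scatter). Read side by side, the two steps look unlike, yet the gap between them stays within what the scatter of two such steps allows: the same change on two cores in this assay, a 2.5-fold lower number (0.40 log units; beyond the scatter) from compound 1 to compound 2 and a 1.0-fold higher number (0.02 log units; within the scatter) from compound 3 to compound 4, 2.6-fold (0.42 log units) apart, within the scatter of two such steps. This does not show that the change behaves differently on the two cores, and it does not show that it behaves alike on them either, so the step on one core gives only a loose guide to the step on the other.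

The compounds shown leave open whether the change would follow either step on a core carrying some other group in place of the 2-(trifluoromethyl)phenyl or the trifluoromethoxy-bearing phenyl group, and no single-place comparison separates those two groups. They also leave open what a methoxy group or an amine would do in place of the hydroxyl on these phenyl rings in this assay.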